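Thiophene in Place of Fluorophenyl on the Oxadiazole

The compounds below may be only part of what the source reports. "The series", "measured", "known", "first", "only" and "open" are said of these compounds alone.

Measured compounds:
compound 1 `O=C(O)CCc1ccc(OCc2ncc(-c3cccc(Cl)c3)o2)cc1` gives 47500 nM
compound 2 `O=C(O)CCc1ccc(OCc2nc(-c3ccc(F)cc3)no2)cc1` gives 680 nM

Both numbers come from a functional assay on CHO cells for agonist activity at Free fatty acid receptor 1 (Homo sapiens), read by FLIPR and calcium flux, in the presence of a further agent that is not named here; a lower number here means that less compound is needed, a higher number that more compound is needed for the effect. Compound 1 `O=C(O)CCc1ccc(OCc2ncc(-c3cccc(Cl)c3)o2)cc1` gives 47500 nM in this assay, while compound 2 `O=C(O)CCc1ccc(OCc2nc(-c3ccc(F)cc3)no2)cc1` gives 680 nM. Going by the values given here, of the two, compound 2 holds the lower number; compound 1 is its only neighbour, and the gap between them lies well beyond the scatter, so compound 2 stands as the more potent of the pair.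

The next step keeps the core of compound 2 and alters the group on its five-membered ring: thiophen-2-yl in place of 4-fluorophenyl on an aromatic carbon. This gives compound 3 `O=C(O)CCc1ccc(OCc2nc(-c3cccs3)no2)cc1`.

Among the compounds with values here, no measured pair shows a step of this kind, so the expectation rests on compound 2 alone and on the nature of the exchange. A five-membered aromatic ring replacing a six-membered one at the same place is often tolerated, and the step of a 1.5-fold higher number from compound 2 to compound 3 (0.17 log units; within the scatter) is expected to be small, if anything a modest rise, close to the scatter. For compound 3 the estimate in this assay is 1000 nM, with a range from 300 nM to 4000 nM.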

Compound 3, half-maximal effective concentration: 2570 nM
Beside the measured number, compound 3's estimate is 2.6-fold (0.41 log units) below it, and the stated range covers the measured number.
By their numbers in this assay, from the lowest: compound 2; then compound 3; then compound 1.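

In this assay, putting thiophen-2-yl in place of 4-fluorophenyl on the aromatic carbon between two ring nitrogen atoms gives a 3.8-fold higher number from compound 2 to compound 3 (0.58 log units; beyond the scatter), which shows that this position of the five-membered ring responds to the identity of the aromatic group it carries. The step is modest, so a five-membered aromatic ring with one hetero atom is accepted here, although compound 3 needs more compound for the effect than the 4-fluorophenyl compound 2 does. Nothing measured in this set accounts for the rise in the number.

The exchange removes the fluorine and changes the ring in a single step, so the compounds shown cannot separate the two, and how a plain phenyl group would stand at this position remains open. Equally open, from the compounds shown here alone, is whether thiophen-3-yl, furan-2-yl or a thiophen-2-yl group bearing a chlorine would bring the number back towards that of compound 2.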